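Swapping the benzylic amine for a quinoline on the shared core

The compounds below may be only part of what the source reports. "The series", "measured", "known", "first", "only" and "open" are said of these compounds alone.

Measured compounds in a functional assay on BT-474 cells (Homo sapiens) for antiproliferative activity, read by MTT assay, with a stated time of 72 h; a lower number here means a stronger inhibitor, a higher number a weaker inhibitor:
compound 1 `CC(Nc1ncnc2ccc(-c3cnn(C4CCNCC4)c3)cc12)c1c(Cl)ccc(F)c1Cl` gives 8130 nM
compound 2 `CC(Nc1nc(N)nc2ccc(-c3cnn(C4CCNCC4)c3)cc12)c1c(Cl)ccc(F)c1Cl` gives 5100 nM
compound 3 `CC(Nc1ncnc2ncc(-c3cnn(C4CCNCC4)c3)cc12)c1c(Cl)ccc(F)c1Cl` gives 13500 nM

Compound 1 lies within the scatter of both others: the step of a 1.6-fold lower number from compound 1 to compound 2 (0.20 log units; within the scatter) is within the scatter, and the numbers of compound 1 and compound 3 also differ only within it. None of the three stands apart from the rest.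

Compound 4 `c1cnc2ccc(Nc3ncnc4ccc(-c5cnn(C6CCNCC6)c5)cc34)cc2c1` differs from compound 1 by quinolin-6-yl in place of 1-(2,6-dichloro-3-fluorophenyl)ethyl on a nitrogen on an aromatic ring. For the measured compounds named here, no measured step concerns this nitrogen substituent; the only step with a number, the one from compound 1 to compound 2, touches the aromatic carbon of the core and was within the scatter, and the change from compound 1 to compound 3 alters the core itself. The group that leaves is large and the group that enters brings an aromatic ring with one heteroatom and one hydrogen-bond acceptor, so the outcome is open. Compound 4 is therefore expected near compound 1, with a wide band: the step of a 1.2-fold higher number from compound 1 to compound 4 (0.09 log units; within the scatter) is estimated as close to none, and compound 4 is expected at 10000 nM within 1500 nM to 60000 nM.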

Compound 4, half-maximal inhibitory concentration: 12900 nM
For compound 4 the middle estimate is 1.3-fold (0.11 log units) below the measured one; the measured number falls inside the stated range.
By their numbers in this assay, from the lowest: compounds 2, 1, 4 and 3 (each within the scatter of the next, the first and the last beyond it).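

This is the only step shown at the nitrogen on an aromatic ring: in this assay, quinolin-6-yl in place of 1-(2,6-dichloro-3-fluorophenyl)ethyl gives a 1.6-fold higher number from compound 1 to compound 4 (0.20 log units; within the scatter). The earlier step concerned an aromatic carbon of the core, so this result shows that the large substituent on the nitrogen can also be exchanged, here for a group with a hetero atom in a ring and a hydrogen-bond acceptor, with the number staying within the scatter of compound 1. No measurement shown accounts for this outcome.

The compounds shown leave open whether any group on this nitrogen can move the number beyond the scatter from compound 1, and a methyl group or a phenyl ring carrying an amine would test this on the same core. Going by these compounds, whether quinolin-6-yl gives a similar result on the core of compound 2 or compound 3 also stays open.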